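The source may report more compounds than this note shows. Statements on the series, on what has been measured and on what is new or still open speak of the compounds shown alone.

In a functional assay on L1210 cells (Mus musculus) for inhibition (on this read-out higher numbers stand for weaker inhibition and lower numbers for stronger inhibition), the measured compounds stand as follows:

- Compound 1 `COc1cccc(/C=C2\CCCc3ccccc3C2=O)c1OC`: > 500000 nM (a limit)
- Compound 2 `O=C1/C(=C/c2ccccc2Cl)Cc2ccccc21`: 152000 nM
- Compound 3 `O=C1/C(=C/c2ccc(Cl)cc2Cl)Cc2ccccc21`: > 500000 nM (a limit)

Compound 1 sits at the limit of > 500000 nM in this assay, at which 2 of the 3 values shown sit, and so gives no exact number. Compound 4 `COc1ccccc1/C=C1\CCCc2ccccc2C1=O` carries hydrogen in place of methoxy on an aromatic carbon. Among the compounds with values here, the only measured step that bears on this runs the other way, adding chloro in place of hydrogen on an aromatic carbon of a different core (an at least 3.2-fold higher number from compound 2 to compound 3 (0.51 log units; beyond the scatter)). Removing the methoxy is therefore expected to lower the number modestly, though this is weak guidance. The estimated step is loose (an at least 2.0-fold lower number from compound 1 to compound 4 (0.30 log units; that floor lies within the scatter)). Compound 4 is expected at 250000 nM within a range of 80000 nM to 700000 nM as an estimate only.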

Compound 4, half-maximal inhibitory concentration: 46100 nM
Compound 4: middle estimate off by 5.4-fold (0.73 log units), on the high side; measured number below the stated range.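

In this assay, within the data shown here, the change gives a first measured step at this place on the aromatic ring, and it lies beyond the scatter: an at least 10-fold lower number from compound 1 to compound 4 (1.03 log units; beyond the scatter). Hydrogen here, ortho to a methoxy group, thus goes with clearly stronger inhibition than methoxy in the shared core. The full size of the step stays unknown because compound 1 stands at a limit: the limit of > 500000 nM in this assay, at which 2 of the 4 values shown sit.

On these data alone, whether a hydroxyl, a fluorine or an amine at this place would match hydrogen remains open. So does whether removing the methoxy has the same effect on the core of compound 2.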